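From Methoxy to Hydroxy: A Small Step Expected

This account rests on a few compounds, and the source may have more. Where it says the series, first, only, none or still open, it means among the compounds named here.

For the measured compounds named here, in a functional assay on A549 cells (Homo sapiens) for cytotoxicity, read by MTT assay (on this read-out lower numbers stand for higher toxicity in this test and higher numbers for lower toxicity in this test), compound 2 (`CO[C@@H](NC(C)=O)[C@H](O)[C@]1(C)CC[C@H](C(C)C)[C@@H]1c1cc([C@]2(O)Cc3cc(O)c(=O)c(C)c4c3[C@@H](O2)[C@H](O)[C@]2(C)CC[C@H](C(C)C)[C@H]42)cc(O)c(=O)c1C`) gives 100 nM as the lower of the two numbers so far, while compound 1 (`CC(=O)O[C@@H](C=O)[C@]1(C)CC[C@H](C(C)C)[C@@H]1c1cc([C@]2(O)Cc3cc(O)c(=O)c(C)c4c3[C@@H](O2)[C@H](O)[C@]2(C)CC[C@H](C(C)C)[C@H]42)cc(O)c(=O)c1C`) gives 320 nM as the higher. Compound 3 (`CC(=O)N[C@H](O)[C@H](O)[C@]1(C)CC[C@H](C(C)C)[C@@H]1c1cc([C@]2(O)Cc3cc(O)c(=O)c(C)c4c3[C@@H](O2)[C@H](O)[C@]2(C)CC[C@H](C(C)C)[C@H]42)cc(O)c(=O)c1C`) differs from compound 2 by hydrogen in place of methyl on an oxygen on a saturated carbon, methoxy to hydroxy (hydrogen in place of methyl on an oxygen on a saturated carbon). Going by the values given here, the only measured step (a 3.2-fold lower number from compound 1 to compound 2 (0.51 log units; beyond the scatter)) is modest and exchanges a larger group, so it is a loose guide. The expected step in this assay (a 1.5-fold higher number from compound 2 to compound 3 (0.18 log units; within the scatter)) is smaller still, toward a slightly higher number and probably within the scatter. For compound 3 the estimated value is 150 nM with a range from 55 nM to 400 nM as the expected span.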

Compound 3, concentration lethal to 50% of the cells: 550 nM
For compound 3 the middle estimate is 3.7-fold (0.56 log units) below the measured one, and the stated range ends below it.
By their numbers in this assay, from the lowest: compound 2; then compounds 1 and 3 (each within the scatter of the next).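

In this assay the swap of methoxy to hydroxy on this saturated carbon gives a 5.5-fold higher number from compound 2 to compound 3 (0.74 log units; beyond the scatter) and so is not a negligible change, with one methyl on that oxygen setting compound 2 apart from the other two. The step of a 1.7-fold higher number from compound 1 to compound 3 (0.24 log units; within the scatter) is no real separation, so among these three side chains only the methoxy form stands apart. Nothing measured here accounts for the size of this change.

From the compounds shown here alone, whether this belongs to the methyl alone stays open. An ethoxy group or an amine on the same carbon would show whether a longer chain or a different atom keeps the lower number.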